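This account rests on a few compounds, and the source may have more. Where it says the series, first, only, none or still open, it means among the compounds named here.

Measured in an assay on isolated protein (Oryctolagus cuniculus) with Thromboxane-A synthase (Homo sapiens) as the target, tested at 1 uM; a lower number here means less inhibition, a higher number more inhibition at the concentration tested (going by the name of the read-out):
Compound 1 `CC(C)n1nc(-c2cccnc2)c2ccccc2c1=O` gives 87%.
Compound 2 `C=CCn1nc(-c2cccnc2)c2ccccc2c1=O` gives 70%.
Compound 3 `O=c1c2ccccc2c(-c2cccnc2)nn1Cc1ccccc1` gives 97%.

Compound 3 has the highest number of the three, but its gap to compound 1 lies within the scatter, so only its distance from compound 2 counts as a real difference. Compound 4 `CC(=O)Cn1nc(-c2cccnc2)c2ccccc2c1=O` is the next compound to consider; it differs from compound 3 in one place: acetyl in place of phenyl on a saturated chain carbon bound to an aromatic nitrogen.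

For the measured compounds named here, one measured step bears on this change: a number 27 percentage points higher from compound 2 to compound 3 (beyond the scatter), where a phenyl arrived at the same chain carbon. Compound 4 removes that phenyl again and puts a smaller acetyl there, so part of that gain is expected to be lost, giving a modest drop a number 25 percentage points lower from compound 3 to compound 4 (beyond the scatter). Compound 4 is therefore estimated at 72%, with a range from 50% to 90%.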

Compound 4, a percentage reported as inhibition, at one concentration (the size of the read-out at that concentration, not a potency): 13%
For compound 4 the middle estimate is 59 percentage points above the measured one; measured number below the stated range.
By their numbers in this assay, from the lowest: compound 4; then compound 2; then compounds 1 and 3 (each within the scatter of the next).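

The position is far less forgiving than isopropyl, allyl and benzyl suggested: in this assay the 2-oxopropyl group brings a number 84 percentage points lower from compound 3 to compound 4 (beyond the scatter) and a number 74 percentage points lower from compound 1 to compound 4 (beyond the scatter) as well as a number 57 percentage points lower from compound 2 to compound 4 (beyond the scatter) in a group no larger than a benzyl. That last step involves no phenyl, so losing the phenyl cannot be the whole story. Nothing available here explains the fall. On these data alone, whether the carbonyl itself goes with the low number stays open. So does how an amine, a carboxylic acid or a longer chain would read on this saturated chain carbon.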